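The source may report more compounds than this note shows. Statements on the series, on what has been measured and on what is new or still open speak of the compounds shown alone.

Compound 1 `COc1ccc(S(=O)(=O)N(CC(C)C)C[C@@H](O)CNC(=O)Oc2ccc3occc3c2)cc1`: in an ADME assay on HEK293 cells (Homo sapiens) for cytotoxicity, read by MTT assay, with a stated time of 24 h (a lower number here means that less compound is tolerated, a higher number that more compound is tolerated), compound 1 reaches only the assay limit, > 60000 nM.
Compound 2 `COc1ccc(S(=O)(=O)N(CC(C)C)C[C@@H](O)CNC(=O)Oc2ccc3sccc3c2)cc1`: in this assay compound 2 likewise gives only the limit, > 60000 nM.

Compound 2 thus stands at the limit, with no number of its own; both values sit at the limit of > 60000 nM in this assay, at which 2 of the 2 values shown sit. For the measured compounds named here, the single measured step, a step that the two limits leave unreadable from compound 1 to compound 2, cannot be read, so no size can be drawn from it. Compound 3 `COc1ccc(S(=O)(=O)N(CC(C)C)C[C@@H](O)CNC(=O)Oc2ccc3[nH]ccc3c2)cc1` differs from compound 2 by 1H-indol-5-yl in place of 1-benzothiophen-5-yl on an oxygen next to a carbonyl group. With no readable step to lean on, compound 3 is expected to sit again at the limit, estimated near 80000 nM, within 30000 nM to 200000 nM. The expected step that the limit leaves unreadable from compound 2 to compound 3 is none beyond the scatter.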

Compound 3, half-maximal cytotoxic concentration: > 60000 nM
Compound 3 gave a limit, no number; the forecaster's own chance of this, stated with the estimate: 75%; the middle value does not contradict the limit.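

Compound 3 also gives only a limit, so the steps among compound 1, compound 2 and compound 3 cannot be read: the limit of > 60000 nM in this assay, at which 3 of the 3 values shown sit. The compounds shown leave open whether these three differ at all in this assay.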